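The source may report more compounds than this note shows. Statements on the series, on what has been measured and on what is new or still open speak of the compounds shown alone.

Compound 1 `COC(=O)c1ccc2ccc(C(=O)N(C)C)c-2cc1`: > 1000 h (a limit)
Compound 2 `O=C(O)c1ccc2ccc(C(=O)c3ccccc3)c-2cc1`: > 1000 h (a limit)

In a physicochemical assay for pharmacokinetics, read by HPLC, with a stated time of 24 h, at pH 7.4, in the presence of a further agent that is not named here (on this read-out lower numbers stand for a shorter-lived compound and higher numbers for a longer-lived compound), compound 1 gives > 1000 h, which is a limit and not a number. Compound 1 therefore stands at the limit of > 1000 h in this assay, at which 2 of the 2 values shown sit, as does compound 2. Compound 3 `CN(C)C(=O)c1ccc2cccccc1-2` has hydrogen in place of methoxycarbonyl on an aromatic carbon. Within the data shown here, no measured step shows what such a change does in this assay. No shift beyond the scatter is expected, and the estimated step is a step that the limit leaves unreadable from compound 1 to compound 3. Compound 3 is estimated at 1200 h, with an expected range from 400 h to 4000 h.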

Compound 3, half-life: > 1000 h
Compound 3 ended at the assay's limit; the forecaster's own chance of this, stated with the estimate: 80%; the middle value does not contradict the limit.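

No step can be read from compound 1 to compound 3, as both values are limits: the limit of > 1000 h in this assay, at which 3 of the 3 values shown sit. The compounds shown leave open how far hydrogen in place of methoxycarbonyl shifts the half-life.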